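Swapping a Benzyl Group for a Thiourea on the Ring Nitrogen

A few compounds are considered here, and "the series" means these few. Any claim that something is new, unique, unknown or untested is made for them only; others in the source may bear on it.

Compound 1 `NC(=O)c1c(NC(=O)c2ccccc2Cl)sc2c1CCN(Cc1ccc([N+](=O)[O-])cc1)C2` and compound 2 `NC(=O)c1c(NC(=O)c2ccccc2Cl)sc2c1CCN(C(=O)Nc1cc(C(F)(F)F)cc(C(F)(F)F)c1)C2` share a core and were both tested in a functional assay on MKN-74 cells (Homo sapiens) for antiproliferative activity, with a stated time of 24 h; a lower number here means a stronger inhibitor, a higher number a weaker inhibitor. In this assay compound 1 gives 31500 nM, and compound 2 gives 24300 nM; the two values sit within the usual scatter of one another, so neither can be called the stronger. Compound 3 `NC(=O)c1c(NC(=O)c2ccccc2Cl)sc2c1CCN(C(=S)Nc1cccnc1)C2` is not yet measured. It differs from compound 1 by a group of 9 heavy atoms (6 carbon, 2 nitrogen, 1 sulfur; one six-membered aromatic ring with 1 hetero atom) in place of a group of 10 heavy atoms (7 carbon, 1 nitrogen, 2 oxygen; one six-membered aromatic ring of carbon only), on an amine nitrogen in a ring. Among the measured compounds shown here, with no measured step of this kind to lean on, the change is expected to move the number little, a 1.4-fold lower number from compound 1 to compound 3 (0.16 log units; within the scatter), and compound 3 is estimated at 22000 nM, in the range 7000 nM to 65000 nM.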

Compound 3, half-maximal inhibitory concentration: 38600 nM
Beside the measured number, compound 3's estimate is 1.8-fold (0.24 log units) below it, and the stated range covers the measured number.
By their numbers in this assay, from the lowest: compounds 2, 1 and 3 (each within the scatter of the next).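

In this assay, putting a thiourea group carrying a six-membered aromatic ring with 1 hetero atom in place of 4-nitrobenzyl on this amine nitrogen gives a 1.2-fold higher number from compound 1 to compound 3 (0.09 log units; within the scatter). So this change of linking group and ring, which also adds a hydrogen-bond donor, leaves no readable difference at this position. Nothing measured here offers an explanation for that. Going by these compounds, whether the thiourea and its ring matter separately remains open. So does whether a simple methyl group, a carboxylic acid or a longer chain ending in an amine on this nitrogen would shift the number.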